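This account rests on a few compounds, and the source may have more. Where it says the series, first, only, none or still open, it means among the compounds named here.

The measured compounds in a functional assay on T47D cells (Homo sapiens) for inhibition, read by sulforhodamine B assay, with a stated time of 48 h (a higher number here means a weaker inhibitor of growth, a lower number a stronger inhibitor of growth), are these three. Compound 1 `COC(=O)[C@@]1(C)CCC=C2[C@@H]1CC[C@@H](C)[C@]2(C)Cc1c[nH]c2c(Br)cccc12` gives 24000 nM. Compound 2 `COC(=O)[C@@]1(C)CCC=C2[C@@H]1CC[C@@H](C)[C@]2(C)Cc1c[nH]c2c(Cl)cccc12` gives 24000 nM. Compound 3 `COC(=O)[C@@]1(C)CCC=C2[C@@H]1CC[C@@H](C)[C@]2(C)Cc1c(C)[nH]c2ccc(Br)cc12` gives 16000 nM.

Compound 1 and compound 2 differ by one change, (chloro in place of bromo on an aromatic carbon), and the step that goes with it is no change at the digits printed from compound 1 to compound 2 (within the scatter). Compound 3 carries a different core; how the core of compound 1 and the core of compound 3 differ is not broken down here. The values of compound 3 and of compound 1 and compound 2 lie within the scatter of one another, so nothing can be said of their order.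

Compound 4 `COC(=O)[C@@]1(C)CCC=C2[C@@H]1CC[C@@H](C)[C@]2(C)Cc1c(C)[nH]c2ccc(Cl)cc12` stands to compound 3 as compound 2 stands to compound 1: the change is chloro in place of bromo on an aromatic carbon. The place is not identical in words, since in compound 1 the halogen sits ortho to a fused ring and meta to a fused ring, while in compound 3 it sits meta to a fused ring and para to a fused ring, so this is the same kind of change rather than the same change.

For compound 4 the step of no change at the digits printed from compound 3 to compound 4 (within the scatter) is expected to be small, because no change at the digits printed from compound 1 to compound 2 (within the scatter) showed no change for the same kind of change. Compound 4 is therefore estimated at 16000 nM in this assay, with a range from 8000 nM to 35000 nM expected.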

Compound 4, concentration for 50% growth inhibition: 17000 nM
Compound 4: middle estimate off by 1.1-fold (0.03 log units), on the low side, within the range that was stated.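

In this assay, among the compounds shown here, chloro in place of bromo on an aromatic carbon gives a 1.1-fold higher number from compound 3 to compound 4 (0.03 log units; within the scatter), so on the core of compound 3, as on the core of compound 1, this change yields no step that can be told from the scatter. Set side by side, the two steps agree: the same change on two cores in this assay, no change at the digits printed (within the scatter) from compound 1 to compound 2 and a 1.1-fold higher number (0.03 log units; within the scatter) from compound 3 to compound 4, 1.1-fold (0.03 log units) apart, within the scatter of two such steps. This shows that, in these two pairs and in this assay, the change carries from one core to the other, even though the halogen stands at a different place on each core, but it does not show that the same would hold on any further core or in any other assay.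

The compounds shown leave open whether a fluoro, a nitrile or an amine on the same aromatic carbon would also stay within the scatter of these values. They also leave open what a carboxylic acid in place of the ester would do on either core.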